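Cytotoxicity of a bicyclic amine series on canine kidney cells

This account rests on a few compounds, and the source may have more. Where it says the series, first, only, none or still open, it means among the compounds named here.

Measured compounds:
- compound 1 `CCc1csc(CN[C@@H]2C[C@H]3C[C@@H]([C@H]2C)C3(C)C)c1`: 25000 nM
- compound 2 `C[C@H]1[C@H](NCc2ccsc2)C[C@H]2C[C@@H]1C2(C)C`: 50000 nM
- compound 3 `C[C@H]1[C@H](NCc2ccco2)C[C@H]2C[C@@H]1C2(C)C`: 50000 nM

In an ADME assay on MDCK cells (Canis lupus familiaris) for cytotoxicity, read by microscopy, with a stated time of 48 h (a higher number here means that more compound is tolerated, a lower number that less compound is tolerated), compound 1 gives 25000 nM, the lowest of the three numbers, though its gap to compound 2 and to compound 3 lies within the scatter. Going by the values given here, the one measured step, no change at the digits printed from compound 2 to compound 3 (within the scatter), swaps one aromatic ring for another on the saturated chain carbon bound to the amine nitrogen and leaves the read-out unchanged. Compound 4 `C[C@H]1[C@H](NCc2cc(-c3ccsc3)cs2)C[C@H]2C[C@@H]1C2(C)C` differs from compound 1 by thiophen-3-yl in place of ethyl on an aromatic carbon. Among the compounds with values here, no measured step touches this position, so the account rests on the flat picture across compounds 1, 2 and 3 in this assay, and no step beyond the scatter is expected. Compound 4 is therefore estimated at 25000 nM (range 8000 nM to 60000 nM), an expected step of no change at the digits printed from compound 1 to compound 4 (within the scatter).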

Compound 4, minimum cytotoxic concentration: 25000 nM
The estimate for compound 4 equals the measured number at the digits printed; measured number inside the range.
By their numbers in this assay, from the lowest: compounds 1, 4, 2 and 3 (each within the scatter of the next).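

In this assay, going by these compounds alone, the step of no change at the digits printed from compound 1 to compound 4 (within the scatter) is the first to touch the aromatic carbon two ring bonds from the ring sulfur. It shows that this position accepts thiophen-3-yl, with 5 heavy atoms and a second aromatic ring, in place of ethyl, with 2 heavy atoms and no ring, without a shift beyond the scatter. Nothing at hand explains why the read-out holds. As far as these compounds go, whether an amine or a carboxylic acid on this carbon would leave the read-out equally flat stays open, as does the outcome for a longer chain there.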